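The source may hold more compounds than are shown below. What is called first, only, known or untested is meant among the compounds shown, and "the series" means these compounds.

Measured so far in a functional assay on T47D cells (Homo sapiens) for inhibition, read by CCK-8 assay, with a stated time of 72 h, tested at 1 uM; on this read-out lower numbers stand for less inhibition of growth and higher numbers for more inhibition of growth at the one concentration tested
- compound 1 `Cc1cccc(NC(=O)C2(C(=O)Nc3ccc(Nc4ncc5cc(C(=O)N(C)C)n(C6CCCC6)c5n4)cc3)CC2)c1` gives 45.7%
- compound 2 `CN(C)C(=O)c1cc2cnc(Nc3ccc(N)cn3)nc2n1C1CCCC1` gives 18.8%

Compound 1 has the higher of the two numbers, and the gap to compound 2 lies beyond the scatter. Compound 3 `COc1ccc(NC(=O)C2(C(=O)Nc3ccc(Nc4ncc5cc(C(=O)N(C)C)n(C6CCCC6)c5n4)cc3)CC2)cc1` has 4-methoxyphenyl in place of 3-methylphenyl on an amide-type nitrogen and keeps the rest of compound 1. Within the data shown here, no measured pair shows this change, so no step beyond the scatter is expected in this assay and the direction stays open. The expected change is a number 1.7 percentage points lower from compound 1 to compound 3 (within the scatter) in this estimate. Compound 3 is expected at 44% with 27% to 61% as the estimated range.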

Compound 3, percent growth inhibition at one concentration: 76.4%
Compound 3: middle estimate off by 32.4 percentage points, on the low side; the measured number lies above the stated range.
By their numbers in this assay, from the lowest: compound 2; then compound 1; then compound 3.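

In this assay the aryl group on the amide-type nitrogen proves a sensitive place: 4-methoxyphenyl in place of 3-methylphenyl gives a number 30.7 percentage points higher from compound 1 to compound 3 (beyond the scatter) with the rest of compound 1 kept. The change alters both the substituent and its number on the phenyl ring, so this single step assigns the gain to neither. No measurement at hand bears on the reason for the step.

Still open, on these data alone, is whether 3-methoxyphenyl or 4-methylphenyl would separate these two changes. As far as these compounds go, it is also open whether 4-aminophenyl or 4-chlorophenyl on this nitrogen would match compound 3.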